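Sulfonyl aryl swap on the scaffold of compound 3

This account rests on a few compounds, and the source may have more. Where it says the series, first, only, none or still open, it means among the compounds named here.

Compound 3 `O=C1[C@@H](NS(=O)(=O)c2cc3cccnc3s2)CCN1Cc1cc2[nH]cccc-2n1` gives 44% in an assay on isolated protein for inhibition of coagulation factor X (Oryctolagus cuniculus), tested at 1 uM (on this read-out higher numbers stand for more inhibition at the one concentration tested (going by the name of the read-out) and lower numbers for less inhibition), the second highest of the three numbers measured. Compound 1 `CC(C)(C)c1ccc(S(=O)(=O)N[C@H]2CCN(Cc3cc4cc[nH]cc-4n3)C2=O)cc1` gives 57% in this assay, a number beyond the scatter above compound 3. Compound 2 `CC(C)(C)c1ccc(S(=O)(=O)N[C@H]2CCN(CCNc3ccncc3)C2=O)cc1` gives 14% in this assay, a number beyond the scatter below compound 3. Among the compounds with values here, the one step between single-change neighbours, a number 43 percentage points lower from compound 1 to compound 2 (beyond the scatter), concerns the group on the saturated chain carbon bound to the amide-type nitrogen in the ring, not the sulfonyl side.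

Compound 4 `CC(C)(C)c1ccc(S(=O)(=O)N[C@H]2CCN(Cc3cc4[nH]cccc-4n3)C2=O)cc1` is reached from compound 3 by a group of 10 heavy atoms (10 carbon; one six-membered aromatic ring of carbon only) in place of a group of 9 heavy atoms (7 carbon, 1 nitrogen, 1 sulfur; one five-membered aromatic ring with 1 hetero atom, one six-membered aromatic ring with 1 hetero atom), on a sulfonyl sulfur. Within the data shown here, no measured step alters the group on the sulfonyl sulfur, so neither the size nor the direction of this change is set by the data. Compound 1 carries the same 4-(tert-butyl)phenyl on the sulfonyl sulfur as compound 4 does; in this assay compound 1 gives 57%. Compound 3 shares the remainder of the molecule with compound 4; in this assay compound 3 gives 44%. The step of a number 6 percentage points higher from compound 3 to compound 4 (within the scatter) is expected to be small, within or barely beyond the scatter. For compound 4 the estimate in this assay is 50%, with a range of 32% to 68%.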

Compound 4, a percentage reported as inhibition, at one concentration (the size of the read-out at that concentration, not a potency): 22%
For compound 4 the middle estimate is 28 percentage points above the measured one, and the stated range ends above it.
By their numbers in this assay, from the lowest: compounds 2 and 4 (each within the scatter of the next); then compound 3; then compound 1.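

In this assay, within the data shown here, the step of a number 22 percentage points lower from compound 3 to compound 4 (beyond the scatter) is the first reading at the sulfonyl sulfur, and it shows that this position is not indifferent on this scaffold: 4-(tert-butyl)phenyl entering for the group with the five-membered and six-membered aromatic rings goes with the lower number. With 4-(tert-butyl)phenyl held fixed, the step of a number 35 percentage points lower from compound 1 to compound 4 (beyond the scatter) shows that the group on the saturated chain carbon bound to the amide-type nitrogen in the ring can matter even when the atom and ring counts stay the same, whereas the step of a number 8 percentage points higher from compound 2 to compound 4 (within the scatter) leaves compound 4 and compound 2 unseparated despite their different groups at that place. Nothing at hand gives a reason for these steps.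

Among these compounds, it remains open whether the sulfonyl swap runs the same way and to the same size when the group of compound 1 sits on the amide-type nitrogen side, since the one reading at the sulfonyl sulfur comes from a single pair. Also open, on these data alone, is how a plain phenyl, or a phenyl carrying a carboxylic acid in place of the tert-butyl, would read on the sulfonyl sulfur.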